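From chloro to tert-butyl in a biaryl amide series

This account rests on a few compounds, and the source may have more. Where it says the series, first, only, none or still open, it means among the compounds named here.

Compound 1 `N#Cc1ccc(NC(=O)c2ccc(-c3ncccc3C(F)(F)F)cc2)cc1` gives 1300 nM in a functional assay for antagonist activity at transient receptor potential cation channel subfamily V member 1 (Rattus norvegicus); a higher number here means a weaker inhibitor, a lower number a stronger inhibitor.
Compound 2 `Cc1cccnc1-c1ccc(C(=O)Nc2ccc(F)cc2)cc1` gives > 4000 nM in this assay, which is a limit of the assay.
Compound 3 `Cc1cccnc1-c1ccc(C(=O)Nc2ccc(Cl)cc2)cc1` gives 2020 nM in this assay.

Of the two numbers shown, compound 3 stands highest; compound 1 lies a little lower, within the scatter, and compound 2 stands at a limit (the limit of > 4000 nM in this assay, at which 1 of the 3 values shown sits). Compound 4 `Cc1cccnc1-c1ccc(C(=O)Nc2ccc(C(C)(C)C)cc2)cc1` differs from compound 3 by tert-butyl in place of chloro on an aromatic carbon. Going by the values given here, the one measured step that bears on it, an at least 1.9-fold lower number from compound 2 to compound 3 (0.29 log units; that floor lies within the scatter), shows chloro doing no worse than fluoro, though its floor lies within the scatter. Among the compounds with values here, no measured compound carries tert-butyl, so the size of this change rests on that single step alone. A lowering of the number is expected for the step of a 2.9-fold lower number from compound 3 to compound 4 (0.46 log units; beyond the scatter). Compound 4 is therefore estimated at 700 nM, with a range from 200 nM to 2500 nM.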

Compound 4, half-maximal inhibitory concentration: 9 nM
For compound 4 the middle estimate is 78-fold (1.89 log units) above the measured one, outside the stated range (below it).
By their numbers in this assay, from the lowest: compound 4; then compounds 1 and 3 (each within the scatter of the next). At a limit, above all of these: compound 2.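

In this assay the step of a 220-fold lower number from compound 3 to compound 4 (2.35 log units; beyond the scatter) is large, and shows that this position, para to a large group, responds far more strongly to tert-butyl than the change from fluoro to chloro had revealed. Against fluoro, the step of an at least 440-fold lower number from compound 2 to compound 4 (2.64 log units; beyond the scatter) gives only a floor, since compound 2 stands at a limit: the limit of > 4000 nM in this assay, at which 1 of the 4 values shown sits. From the compounds shown here alone, whether a smaller isopropyl or a cyclopropyl group here would give a similar gain stays open, as does the effect of a trifluoromethyl group at this position.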